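Replacing a tetrazole methyl with 4-chlorophenyl

The compounds below may be only part of what the source reports. "The series", "measured", "known", "first", "only" and "open" are said of these compounds alone.

Of the compounds shown here, two with a shared core have so far been measured in an assay on microsomes from brain for inhibition of Fatty-acid amide hydrolase 1 (Rattus norvegicus), read by fluorescence and HPLC, with a stated time of 60 min; a lower number here means a stronger inhibitor, a higher number a weaker inhibitor. Compound 1 `CCCCCCCCc1ccc(OCC(=O)Cn2nnc(SC)n2)cc1` gives 31 nM in this assay. Compound 2 `CCCCCCCCc1ccc(OCC(=O)Cn2nnnc2C)cc1` gives 41 nM in this assay. Within the data shown here, the only step between measured compounds, a 1.3-fold higher number from compound 1 to compound 2 (0.12 log units; within the scatter), exchanges one tetrazole arrangement for another and stays within the scatter. Compound 2 therefore holds the highest of the two numbers, with compound 1 as its nearest neighbour, the two indistinguishable within the scatter.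

The unmeasured compound 3 `CCCCCCCCc1ccc(OCC(=O)Cn2nnnc2-c2ccc(Cl)cc2)cc1` differs from compound 2 in one place: 4-chlorophenyl in place of methyl on an aromatic carbon. Among the measured compounds shown here, no measured step touches this kind of exchange, since the single step on record changes the tetrazole itself rather than the group on its aromatic carbon, so it offers no direction for this assay. With that, compound 3 is expected to give a number close to that of compound 2, and the step of a 1.0-fold lower number from compound 2 to compound 3 (0.01 log units; within the scatter) is estimated to stay near the scatter. The estimate for compound 3 in this assay is 40 nM, expected between 10 nM and 160 nM.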

Compound 3, half-maximal inhibitory concentration: 130 nM
Compound 3: middle estimate off by 3.3-fold (0.51 log units), on the low side; measured number inside the range.
By their numbers in this assay, from the lowest: compounds 1 and 2 (each within the scatter of the next); then compound 3.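

In this assay, 4-chlorophenyl in place of methyl gives a 3.2-fold higher number from compound 2 to compound 3 (0.50 log units; beyond the scatter), the only step shown that lies beyond the scatter. This aromatic carbon, between two ring nitrogen atoms, therefore responds to an exchange of its group, which could not be learned from the earlier pair, whose one step changed the ring arrangement and stayed within the scatter. The size of this step is modest, and no measurement at hand speaks to what lies behind it.

As far as these compounds go, what a plain phenyl without the chlorine, an ethyl group or an amine would give on this same carbon stays open, so the rise cannot yet be divided between the added ring and the chlorine. Also open is whether 4-chlorophenyl in place of the methylsulfanyl group of compound 1 would move the number in the same direction, since the one exchange shown starts from the methyl of compound 2.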